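Amino to methoxy on an aromatic carbon: a forecast for compound 3

A few compounds are considered here, and "the series" means these few. Any claim that something is new, unique, unknown or untested is made for them only; others in the source may bear on it.

Measured so far:
compound 1, `COc1cc(-c2cc(/C=C/C(=O)c3ccc(N)cc3)[nH]n2)cc(OC)c1OC`: -92%
compound 2, `COc1ccc(-c2cc(/C=C/C(=O)c3ccc(N)cc3)[nH]n2)cc1OC`: -86%

Of the compounds shown here, two have been measured in a functional assay on UACC-62 cells (Homo sapiens) for cytotoxicity, read by sulforhodamine B assay, with a stated time of 48 h, tested at 100 uM; a lower number here means a stronger effect, a higher number a weaker effect of the compound at the concentration tested. Compound 1 gives the lowest of the two numbers, and compound 2 stands nearest to it; the two are within the usual scatter of each other, so neither can be set apart from the other. Going by the values given here, the only step between measured compounds, a number 6 percentage points higher from compound 1 to compound 2 (within the scatter), concerns hydrogen in place of methoxy on an aromatic carbon and does not reach beyond the scatter.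

Compound 3, `COc1ccc(C(=O)/C=C/c2cc(-c3cc(OC)c(OC)c(OC)c3)n[nH]2)cc1`, is not yet measured. It differs from compound 1 by methoxy in place of amino on an aromatic carbon. Among the compounds with values here, no measured step touches this part of the shared core: the one step known concerns a different group on a different ring, so it bears on this change only indirectly, by showing that a small change at the edge of the molecule left the read-out where it was.

On that basis the step of a number 7 percentage points higher from compound 1 to compound 3 (within the scatter) is expected to stay within the scatter, with wide uncertainty. For compound 3 the estimate is -85%, with a range from -100% to -55%.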

Compound 3, a percentage reported as activity, at one concentration (the size of the read-out at that concentration, not a potency): -48%
For compound 3 the middle estimate is 37 percentage points below the measured one, and the stated range ends below it.
By their numbers in this assay, from the lowest: compounds 1 and 2 (each within the scatter of the next); then compound 3.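

In this assay, going by these compounds alone, putting methoxy in place of amino on the aromatic carbon para to a large group gives a number 44 percentage points higher from compound 1 to compound 3 (beyond the scatter), the first step in this small set to pass beyond the scatter. Within the data shown here, the only earlier step, a number 6 percentage points higher from compound 1 to compound 2 (within the scatter), concerned a different ring and left the read-out within the scatter, so the result shows that this read-out can respond strongly to a single change in the molecule, and that the 4-aminophenyl to 4-methoxyphenyl exchange is such a change. Nothing available explains why this exchange has so large an effect.

On these data alone, with only amino and methoxy seen at this position, it remains open whether the step reflects the departure of amino or the arrival of methoxy, and a hydroxy group, a dimethylamino group or an acetamido group placed there could help to separate the two. As far as these compounds go, it also remains open whether the same exchange would produce a step of similar size on the core of compound 2.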